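A few compounds are considered here, and "the series" means these few. Any claim that something is new, unique, unknown or untested is made for them only; others in the source may bear on it.

Working notes on the series, read in an ADME assay on L132 cells (Homo sapiens) for cytotoxicity, read by MTT assay, with a stated time of 48 h; on this read-out lower numbers stand for stronger inhibition and higher numbers for weaker inhibition. Compound 3 `C/C(=C\CC/C(C)=C/CC[C@@H]1[C@@]2(C)CCC(=O)C(C)(C)[C@H]2CC[C@@]1(C)O)CC/C=C(\C)C(=O)OCc1cn(-c2ccccc2F)nn1` gives > 150000 nM, which is a limit and not a number. Compound 1 `COc1ccccc1-n1cc(COC(=O)/C(C)=C/CC/C(C)=C/CC/C(C)=C/CC[C@@H]2[C@@]3(C)CCC(=O)C(C)(C)[C@H]3CC[C@@]2(C)O)nn1` gives > 150000 nM, also a limit. Compound 2 `C/C(=C\CC/C(C)=C/CC[C@@H]1[C@@]2(C)CCC(=O)C(C)(C)[C@H]2CC[C@@]1(C)O)CC/C=C(\C)C(=O)OCc1cn(-c2ccc(C(F)(F)F)cc2)nn1` gives > 150000 nM, again a limit. Compound 3 therefore has no measured position relative to the other two, and all three sit at the limit of > 150000 nM in this assay, at which 3 of the 3 values shown sit.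

The next compound, compound 4 `C/C(=C\CC/C(C)=C/CC[C@@H]1[C@@]2(C)CCC(=O)C(C)(C)[C@H]2CC[C@@]1(C)O)CC/C=C(\C)C(=O)OCc1cn(-c2cccc(O)c2)nn1`, has 3-hydroxyphenyl in place of 2-fluorophenyl on an aromatic nitrogen of a five-membered aromatic ring with 3 nitrogen: 3-hydroxyphenyl in place of 2-fluorophenyl on an aromatic nitrogen. The shared core and chain stay unchanged.

The closest precedents also change the group on that nitrogen: a step that the two limits leave unreadable from compound 1 to compound 3, a step that the two limits leave unreadable from compound 2 to compound 3 and a step that the two limits leave unreadable from compound 1 to compound 2. None of these gives a readable size or direction. These steps show only that 2-methoxyphenyl, 4-(trifluoromethyl)phenyl and 2-fluorophenyl all leave the compounds at the limit.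

No step beyond the scatter is therefore expected in this assay, and no direction is predicted. The expected change is a step that the limit leaves unreadable from compound 3 to compound 4. A further report of only a limit is the most likely result. For compound 4 the estimated value is 160000 nM, with an expected range from 90000 nM to 300000 nM.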

Compound 4, half-maximal inhibitory concentration: 146000 nM
Estimate against measurement, compound 4: 1.1-fold (0.04 log units) above, and the stated range covers the measured number.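

In this assay compound 4 is the first compound shown with a number and not a limit, so a change of the group on the aromatic nitrogen can now be read from one side at least. The steps are an at least 1.0-fold lower number from compound 3 to compound 4 (0.01 log units; that floor lies within the scatter) and an at least 1.0-fold lower number from compound 2 to compound 4 (0.01 log units; that floor lies within the scatter) and also an at least 1.0-fold lower number from compound 1 to compound 4 (0.01 log units; that floor lies within the scatter) and none of these floors goes beyond the scatter, so 3-hydroxyphenyl is not shown to differ from 2-fluorophenyl, 4-(trifluoromethyl)phenyl or 2-methoxyphenyl at this position. The number for compound 4 therefore adds a measured value without adding a measured difference, and the series still sits mostly at the assay limit: the limit of > 150000 nM in this assay, at which 3 of the 4 values shown sit.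

Open, as far as these compounds go, is whether any group on this nitrogen gives a step beyond the scatter, since the true values behind the three limits remain unknown. An amine or a carboxylic acid in place of the hydroxyl on the phenyl ring, or a longer chain between the phenyl ring and the aromatic nitrogen, would put that question to this position.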